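This account rests on a few compounds, and the source may have more. Where it says the series, first, only, none or still open, it means among the compounds named here.

Measured in a functional assay on RAW264.7 cells (Mus musculus), read by fluorescence; on this read-out higher numbers stand for weaker inhibition and lower numbers for stronger inhibition:

compound 1 `CCOC(=O)C1=CCCCC1S(=O)(=O)Cc1ccc(Cl)cc1F` gives 104 nM
compound 2 `CCOC(=O)C1=CCCCC1S(=O)(=O)Cc1ccc(Cl)c(Cl)c1` gives 53 nM
compound 3 `CCOC(=O)C1=CCCCC1S(=O)(=O)Cc1ccc(Cl)cc1Cl` gives 60 nM

The three compounds share one core and differ only in the substitution of the aromatic ring. Compounds 2 and 3 hold the same atoms joined differently; how their cores differ is not broken down here. What their two values show is a gap that lies within the scatter, so neither is set above the other. From compound 3 to compound 1 the change is fluoro in place of chloro on an aromatic carbon and the step is a 1.7-fold higher number from compound 3 to compound 1 (0.24 log units; within the scatter).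

Compound 4 `CCOC(=O)C1=CCCCC1S(=O)(=O)Cc1ccc(F)c(Cl)c1` is not yet measured. It arises from compound 2 by fluoro in place of chloro on an aromatic carbon. This is the same kind of change as that from compound 3 to compound 1, but not the same: there the entering fluoro sits ortho to a large group and meta to a chloro group, here it sits ortho to a chloro group and para to a large group.

For compound 4 in this assay the step from compound 2 is expected to be a 1.5-fold higher number from compound 2 to compound 4 (0.18 log units; within the scatter), resting on the measured step of a 1.7-fold higher number from compound 3 to compound 1 (0.24 log units; within the scatter) and on the starting value of compound 2, 53 nM. For the measured compounds named here, only one such step is known, and its place on the ring differs, so the expected range is kept wide. Compound 4 is estimated at 80 nM, between 40 nM and 170 nM.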

Compound 4, half-maximal inhibitory concentration: 13 nM
For compound 4 the middle estimate is 6.2-fold (0.79 log units) above the measured one; measured number below the stated range.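

In this assay, fluoro in place of chloro on an aromatic carbon, entering ortho to a chloro group and para to a large group, gives a 4.1-fold lower number from compound 2 to compound 4 (0.61 log units; beyond the scatter). Set beside the earlier case, this change does not carry from one core to the other as a fixed step: the same change on two cores in this assay, a 1.7-fold higher number (0.24 log units; within the scatter) from compound 3 to compound 1 and a 4.1-fold lower number (0.61 log units; beyond the scatter) from compound 2 to compound 4, 7.1-fold (0.85 log units) apart, beyond the scatter of two such steps The two pairs also differ in where the fluoro enters, and with a single pair on each side the result shows only that the size and direction of the step depend on its setting, not which feature of that setting decides them, so no rule for other cores follows.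

The compounds shown leave open whether other groups, such as bromo, methyl or methoxy, would follow compound 4 or compound 2 when set ortho to a chloro group and para to a large group. Also open, on these data alone, is whether the step seen with compound 4 would hold on a core in which the ethyl ester gives way to a carboxylic acid or an amide.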